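The compounds below may be only part of what the source reports. "The series", "measured", "known", "first", "only" and "open" are said of these compounds alone.

Measured in a functional assay on COLO 205 cells (Homo sapiens) for antiproliferative activity; a lower number here means a stronger inhibitor of growth, a higher number a weaker inhibitor of growth:
- compound 1 `COCCCCCCCCCCCCCCC/C=C1/CC(CO)(COC(=O)C(C)(C)C)OC1=O`: 0.178 ug/mL
- compound 2 `COCCCCCCCCCCCCCCC/C=C1\CC(CO)(COC(=O)C(C)(C)C)OC1=O`: 0.118 ug/mL

Compound 2 cannot be separated from compound 1 on these numbers. Within the data shown here, the only measured step is a 1.5-fold lower number from compound 1 to compound 2 (0.18 log units; within the scatter), and it concerns the double bond, drawn Z in one compound and E in the other.

Compound 3 `COCCCCCCCCCCC/C=C1\CC(CO)(COC(=O)C(C)(C)C)OC1=O` keeps the double bond of compound 2 and carries methoxy in place of 4-methoxybutyl on a saturated chain carbon, ten or more bonds along the chain from a double-bonded chain carbon. Among the measured compounds shown here, no measured step changes the chain, so a 1.5-fold lower number from compound 1 to compound 2 (0.18 log units; within the scatter) offers no direct guide to this change. In this assay, no shift beyond the scatter is expected, though the uncertainty is wide in both directions. The expected step is a 1.4-fold higher number from compound 2 to compound 3 (0.16 log units; within the scatter). For compound 3 the estimated value is 0.17 ug/mL, with an expected range of 0.05 ug/mL to 0.6 ug/mL.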

Compound 3, concentration for 50% growth inhibition: 0.541 ug/mL
Estimate against measurement, compound 3: 3.2-fold (0.50 log units) below; measured number inside the range.
By their numbers in this assay, from the lowest: compounds 2 and 1 (each within the scatter of the next); then compound 3.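

In this assay, methoxy in place of 4-methoxybutyl on a saturated chain carbon, ten or more bonds along the chain from a double-bonded chain carbon, gives a 4.6-fold higher number from compound 2 to compound 3 (0.66 log units; beyond the scatter) and shows that this part of the chain is not silent. Among these compounds, the earlier change at the double bond gave a 1.5-fold lower number from compound 1 to compound 2 (0.18 log units; within the scatter) and stayed within the scatter, so this is the first step to go beyond it. Nothing at hand bears on why the chain change moves the number.

As far as these compounds go, whether the number follows chain length gradually or changes only at a certain length stays open, since a single pair with one double-bond geometry carries this step. Also open, from the compounds shown here alone, is the outcome for a longer chain than in compound 2, or for a carboxylic acid or an amine in place of the methoxy.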